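Swapping a propyl for cyclopropyl on the pyridone nitrogen

The source may report more compounds than this note shows. Statements on the series, on what has been measured and on what is new or still open speak of the compounds shown alone.

Of the compounds shown here, three sharing one core have been measured in a functional assay on CHO cells for positive allosteric modulation of metabotropic glutamate receptor 2 (Homo sapiens), read by scintillation counting and GTPgammaS binding, with a stated time of 30 min; a higher number here means that more compound is needed for the effect, a lower number that less compound is needed. Compound 1 `CC(C)CCn1ccc(-c2ccc(OC3CCCC3)c(Cl)c2)c(C#N)c1=O` gives 100 nM. Compound 2 `CCCCn1ccc(-c2ccc(Oc3ccnc(C)c3)cc2)c(C#N)c1=O` gives 398 nM, and compound 3 `CCCCn1ccc(-c2ccc(Oc3cccnc3C)cc2)c(C#N)c1=O` gives 347 nM. Within the data shown here, the one single-point step among them, a 1.1-fold lower number from compound 2 to compound 3 (0.06 log units; within the scatter), changes only the pyridyl ring on the oxygen and leaves the number essentially unchanged. Compound 3 thus sits in the upper part of this small set: its number matches that of compound 2 within the scatter, while compound 1, which differs from it at several places at once, shows the lowest number of the three.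

Compound 4 `Cc1ncccc1Oc1ccc(-c2ccn(CC3CC3)c(=O)c2C#N)cc1` differs from compound 3 by cyclopropyl in place of propyl on a saturated chain carbon bound to an aromatic nitrogen. Among the measured compounds shown here, no measured step touches this chain on the aromatic nitrogen; the only recorded step concerns the pyridyl ring, so there is nothing here that speaks for or against a change from this alteration. The expected step of a 1.2-fold lower number from compound 3 to compound 4 (0.06 log units; within the scatter) is therefore set to stay within the scatter, with no direction. Compound 4 is accordingly expected to give about 300 nM in this assay, in a range from 120 nM to 800 nM.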

Compound 4, half-maximal effective concentration: 1070 nM
For compound 4 the middle estimate is 3.6-fold (0.55 log units) below the measured one; measured number above the stated range.
By their numbers in this assay, from the lowest: compound 1; then compounds 3 and 2 (each within the scatter of the next); then compound 4.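

Among these compounds, this is the first measured step that touches the chain on the aromatic nitrogen, and in this assay the change of propyl to cyclopropyl gives a 3.1-fold higher number from compound 3 to compound 4 (0.49 log units; beyond the scatter). Read one bond further out, this is butyl to cyclopropylmethyl, a swap that leaves the heavy-atom count as it was and brings in no hydrogen-bond donor, hydrogen-bond acceptor or charge, so closing a ring at this place is enough to move the number beyond the scatter, unlike the pyridyl change in a 1.1-fold lower number from compound 2 to compound 3 (0.06 log units; within the scatter). No measurement shown here accounts for this rise.

As far as these compounds go, all of this rests on a single pair of compounds, so it remains open whether the same change would give a similar step with a different group on the oxygen. Also open, from the compounds shown here alone, is how the number responds to other groups at this place, such as a longer chain like hexyl, a larger ring like cyclobutyl, or an amine at the end of the chain.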